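A Chloro Substituent Carried From One Core to Another

The compounds below may be only part of what the source reports. "The series", "measured", "known", "first", "only" and "open" are said of these compounds alone.

The measured compounds and their values in a functional assay on the whole organism with Rattus norvegicus as the target (a higher number here means a weaker inhibitor, a lower number a stronger inhibitor), are these:
compound 1, `Cc1ccc(O)c(N(CCCN2CCN(C(c3ccccc3)c3ccc(Cl)cc3)CC2)C(C)C)c1`, gives 0.44 ug/mL
compound 2, `Cc1ccc(O)c(N(CCCN2CCN(C(c3ccc(Cl)cc3)c3ccc(Cl)cc3)CC2)C(C)C)c1`, gives 2.2 ug/mL
compound 3, `Cc1ccc(O)c(NCCCN2CCC(OC(c3ccccc3)c3ccccc3)CC2)c1`, gives 0.036 ug/mL

Compound 1 and compound 2 share a core and differ in one place: chloro in place of hydrogen on an aromatic carbon. In this assay that change brought a 5.0-fold higher number from compound 1 to compound 2 (0.70 log units; beyond the scatter). Compound 3 stands on a different core; how the two cores differ is not broken down here. In this assay compound 3 has the lowest of the three numbers, and the steps from compound 3 to compound 1 and to compound 2 are both beyond the scatter.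

Compound 4, `Cc1ccc(O)c(NCCCN2CCC(OC(c3ccccc3)c3ccc(Cl)cc3)CC2)c1`, has not yet been measured. It differs from compound 3 in the same way that compound 2 differs from compound 1: chloro in place of hydrogen on an aromatic carbon. The place is the same in both pairs, so this is the same change on a different core.

Within the data shown here, the expectation for compound 4 rests on compound 1 and compound 2, because a 5.0-fold higher number from compound 1 to compound 2 (0.70 log units; beyond the scatter) is the only measured example of this change, and a step of similar size is expected here, namely a 4.2-fold higher number from compound 3 to compound 4 (0.62 log units; beyond the scatter). Compound 4 is therefore estimated at 0.15 ug/mL in this assay, with a plausible range from 0.05 ug/mL to 0.5 ug/mL.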

Compound 4, half-maximal inhibitory concentration: 0.084 ug/mL
Estimate against measurement, compound 4: 1.8-fold (0.25 log units) above, and the stated range covers the measured number.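

In this assay, the change from phenyl to 4-chlorophenyl again raised the number, a 2.3-fold higher number from compound 3 to compound 4 (0.37 log units; beyond the scatter), so the direction seen on the core of compound 1 held on the core of compound 3. The size of the step carried over as well, as far as two pairs can tell, since the two steps cannot be told apart: the same change on two cores in this assay, a 5.0-fold higher number (0.70 log units; beyond the scatter) from compound 1 to compound 2 and a 2.3-fold higher number (0.37 log units; beyond the scatter) from compound 3 to compound 4, 2.1-fold (0.33 log units) apart, within the scatter of two such steps This does not show that the change would behave alike on any further core, rests on a single assay, and gives no reason for the loss of potency; moreover, the chloro in compound 2 joins one already present in compound 1, whereas the chloro in compound 4 is the only one in that molecule.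

The compounds shown leave open whether fluoro, methyl or methoxy in the same place would bring a step of the same direction, and what a second chloro on the remaining phenyl of compound 4 would do. Among these compounds, they also leave open whether the same change would hold up with a longer chain in place of the one that these four compounds carry.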